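Adding a Bromine to a Series That Stays Silent

This account rests on a few compounds, and the source may have more. Where it says the series, first, only, none or still open, it means among the compounds named here.

Three compounds share a core and are compared in a functional assay on Ehrlich cells (Mus musculus) for antiproliferative activity; a lower number here means a stronger inhibitor, a higher number a weaker inhibitor. Compound 1, `Cc1c(C(=O)/C=C/N(C)C)c(C(=O)Nc2ccccc2)nn1-c1ccccc1`, in this assay gives > 100 ug/mL, which is a limit of the assay rather than a number. Compound 2, `CC(=O)c1nn(-c2ccccc2)cc1C(=O)c1c(C(=O)Nc2ccccc2)nn(-c2ccccc2)c1C`, in this assay gives > 100 ug/mL, again a limit. Compound 3, `CCOC(=O)c1nn(-c2ccccc2)cc1C(=O)c1c(C(=O)Nc2ccccc2)nn(-c2ccccc2)c1C`, in this assay gives > 100 ug/mL, also a limit. For the measured compounds named here, the one step measured between neighbours, a step that the two limits leave unreadable from compound 2 to compound 3, has both of its ends at a limit and so cannot be read. Compound 3 therefore stands where every value in this set stands: at the limit of > 100 ug/mL in this assay, at which 3 of the 3 values shown sit.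

Compound 4, `CCOC(=O)c1nn(-c2ccc(Br)cc2)cc1C(=O)c1c(C(=O)Nc2ccccc2)nn(-c2ccccc2)c1C`, differs from compound 3 in one place: bromo in place of hydrogen on an aromatic carbon. Going by the values given here, no measured step involves this kind of change, and the only measured step between neighbours is unreadable, so there is no ground for expecting a shift in either direction in this assay. Compound 4 is expected to show a number no higher from compound 3 to compound 4 (the limit leaves the size open), a step no larger than the usual scatter. Compound 4 is estimated at 100 ug/mL in this assay, with a range from 40 ug/mL to 300 ug/mL, and the most likely outcome is that only a limit is reported once more.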

Compound 4, half-maximal inhibitory concentration: > 100 ug/mL
Compound 4: a limit, no number; the forecaster's own chance of this, stated with the estimate: 80%; the middle value sits exactly at the limit.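

Compound 3 and compound 4 each give only a limit in this assay, not a number, so the step between them cannot be read. All the compounds shown stand at the same place: (the limit of > 100 ug/mL in this assay, at which 4 of the 4 values shown sit). They leave open how weak each compound really is, and whether any change to the shared core would give a measurable value.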